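Urea aryl variation: quinoline to isoquinoline exchange

The source may report more compounds than this note shows. Statements on the series, on what has been measured and on what is new or still open speak of the compounds shown alone.

Notes on the urea series. Compound 1 `CN(C)C1(Cc2ccccc2)CCN(c2cc(C(F)(F)F)ccc2CNC(=O)Nc2cccc3c2CC(O)CC3)CC1` gives 0.95 nM in an assay on CHO cells for displacement of a labelled ligand from transient receptor potential cation channel subfamily V member 1 (Homo sapiens), read by scintillation counting, with a stated time of 60 min; on this read-out lower numbers stand for stronger inhibition and higher numbers for weaker inhibition. Compound 2 `CN(C)C1(Cc2ccccc2)CCN(c2cc(C(F)(F)F)ccc2CNC(=O)Nc2ccc3c(c2)OCC3)CC1` gives 41.4 nM, and compound 3 `CN(C)C1(Cc2ccccc2)CCN(c2cc(C(F)(F)F)ccc2CNC(=O)Nc2ccc3cccnc3c2)CC1` gives 14.1 nM. On these numbers compound 3 stands second highest of the three: the nearest neighbour is the step of a 2.9-fold lower number from compound 2 to compound 3 (0.47 log units; beyond the scatter), the furthest the step of a 15-fold higher number from compound 1 to compound 3 (1.17 log units; beyond the scatter). All three measured steps change only the bicyclic group on the urea nitrogen, and two of them are large, so this position is clearly responsive to the group placed there.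

Compound 4 `CN(C)C1(Cc2ccccc2)CCN(c2cc(C(F)(F)F)ccc2CNC(=O)Nc2cccc3ccncc23)CC1` is the next member, and its change from compound 3 is isoquinolin-8-yl in place of quinolin-7-yl on an amide-type nitrogen; the two have the same atoms, joined differently. Going by the values given here, no measured pair compares two aromatic bicycles that differ only in how the same atoms are joined, so the steps of a 15-fold higher number from compound 1 to compound 3 (1.17 log units; beyond the scatter) and a 2.9-fold lower number from compound 2 to compound 3 (0.47 log units; beyond the scatter) show only that the site matters, not in which direction an isomeric swap will move. Among the compounds with values here, with no direct precedent, the step of a 1.1-fold higher number from compound 3 to compound 4 (0.03 log units; within the scatter) is expected to stay within or close to the scatter, with a wide range to cover either direction. Compound 4 is therefore estimated at 15 nM, with a range from 4 nM to 60 nM.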

Compound 4, inhibition constant: 12.3 nM
Compound 4: the middle estimate sits 1.2-fold (0.09 log units) above what was measured; the range from low to high includes it.
By their numbers in this assay, from the lowest: compound 1; then compounds 4 and 3 (each within the scatter of the next); then compound 2.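

Going by these compounds alone, the swap of quinolin-7-yl for isoquinolin-8-yl gives the first direct reading on two aromatic bicycles that have the same atoms joined differently, and in this assay it does not separate them (a 1.1-fold lower number from compound 3 to compound 4 (0.06 log units; within the scatter)). At this amide-type nitrogen, then, this particular rejoining of the atoms leaves the read-out within the usual scatter. Compound 4 also stands apart from the other two bicycles much as compound 3 does, with a modest step from one (a 3.4-fold lower number from compound 2 to compound 4 (0.53 log units; beyond the scatter)) and a large step from the other (a 13-fold higher number from compound 1 to compound 4 (1.11 log units; beyond the scatter)), so the large gap to compound 1 is not confined to a single nitrogen bicycle. Nothing at hand gives a measured reason for these results.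

Going by these compounds, it remains open whether the hydroxyl of the 3-hydroxy-1,2,3,4-tetrahydronaphthalen-5-yl group in compound 1 is needed for its value, which a version carrying an amine or a methoxy group in its place would test. On these data alone, it is also open whether the ring nitrogen matters at all, which a naphthyl group on the same urea nitrogen would show against compound 3 and compound 4.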